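The compounds below may be only part of what the source reports. "The series", "measured", "known", "first", "only" and "open" are said of these compounds alone.

Measured compounds:
compound 1, `N#Cc1c(-c2ccccc2)nc(SCC(=O)Nn2c(COc3ccc(Cl)cc3Cl)nc3ccccc3c2=O)[nH]c1=O`, 81.8%
compound 2, `N#Cc1c(-c2ccc(Cl)cc2)nc(SCC(=O)Nn2c(COc3ccc(Cl)cc3Cl)nc3ccccc3c2=O)[nH]c1=O`, 63.6%
compound 3, `N#Cc1c(Nc2ccccc2)nc(SCC(=O)Nn2c(COc3ccc(Cl)cc3Cl)nc3ccccc3c2=O)nc1-c1ccccc1`, 77.3%

All numbers come from a functional assay on the whole organism (strain albino) for inhibition, with Rattus norvegicus as the target, read by paw edema, with a stated time of 1 h, at a dose of 100 mg/kg by the oral route; a lower number here means less inhibition, a higher number more inhibition at the dose given (going by the name of the read-out). Compound 1 and compound 2 share a core and differ in one place, (chloro in place of hydrogen on an aromatic carbon). In this assay the step of a number 18.2 percentage points lower from compound 1 to compound 2 (beyond the scatter). Compound 3 carries a different core; the difference between the two cores is not broken down here. In this assay compound 3 gives 77.3%, which lies within the scatter of the number for compound 1, so no order between the two is read from it; the number for compound 2 lies beyond the scatter below it.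

Compound 4, `N#Cc1c(Nc2ccccc2)nc(SCC(=O)Nn2c(COc3ccc(Cl)cc3Cl)nc3ccccc3c2=O)nc1-c1ccc(Cl)cc1`, has not been measured. It differs from compound 3 by chloro in place of hydrogen on an aromatic carbon, and the surroundings of the place read the same as for the change from compound 1 to compound 2, so it is the same change made on the other core. Whether the other core carries the effect is not known from the three measured compounds. Within the data shown here, for compound 4 the step of a number 14.3 percentage points lower from compound 3 to compound 4 (beyond the scatter) is expected in this assay, resting on the step of a number 18.2 percentage points lower from compound 1 to compound 2 (beyond the scatter), kept somewhat smaller since only one example is at hand. The estimate for compound 4 is 63%, expected to fall between 50% and 76%.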

Compound 4, a percentage reported as inhibition, in the whole organism at one dose (the size of the read-out at that dose, not a potency): 43.6%
The estimate for compound 4 lay 19.4 percentage points above the measured number; the measured number lies below the stated range.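

In this assay, the change from phenyl to 4-chlorophenyl lowers the number on the second core as it does on the first, the new step being a number 33.7 percentage points lower from compound 3 to compound 4 (beyond the scatter), so the direction of the step holds on both cores shown. Among these compounds, the size of the step does not carry over from one core to the other: the same change on two cores in this assay, a number 18.2 percentage points lower (beyond the scatter) from compound 1 to compound 2 and a number 33.7 percentage points lower (beyond the scatter) from compound 3 to compound 4, 15.5 percentage points apart, beyond the scatter of two such steps With only one pair per core, this shows that the direction held twice, not that it is a general rule for the series, and it does not show which feature of the two cores goes with the larger step.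

On these data alone, it remains open whether the lower number belongs to chloro itself or would follow any group at that place, which fluoro, methoxy or a carboxylic acid on the same ring could show. Also open, as far as these compounds go, is whether the direction of the step and the gap between the two steps would hold on a third core or at other doses and read times.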